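One Attachment Swap, Tried on a Second Chain

A few compounds are considered here, and "the series" means these few. Any claim that something is new, unique, unknown or untested is made for them only; others in the source may bear on it.

Measured so far:
Compound 1 `Clc1ccc2c(NCCNc3nccc(Cl)n3)ccnc2c1`: 2850 nM
Compound 2 `Clc1ccc2c(NCCCNc3nccc(Cl)n3)ccnc2c1`: 1810 nM
Compound 3 `Clc1ccc2c(NCCNc3ccnc(Cl)n3)ccnc2c1`: 2090 nM

Three compounds have been run in a physicochemical assay for solubility, read by HPLC, measured as octanol-water partition, at pH 7.4 (on this read-out higher numbers stand for higher solubility and lower numbers for lower solubility), and all three values lie close together. Compound 1 and compound 3 share the same core and differ in one place: 2-chloropyrimidin-4-yl in place of 4-chloropyrimidin-2-yl on an amine nitrogen. That swap produced a 1.4-fold lower number from compound 1 to compound 3 (0.13 log units; within the scatter), so the two cannot be ranked against each other. Compound 2 carries a different chain between the two amine nitrogens; how its core differs from that of compound 1 is not broken down here, and its value simply sits alongside the other two within the usual scatter.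

Compound 4 `Clc1ccc2c(NCCCNc3ccnc(Cl)n3)ccnc2c1` has not yet been measured. It is made from compound 2 by the same change already seen between compound 1 and compound 3: 2-chloropyrimidin-4-yl in place of 4-chloropyrimidin-2-yl on an amine nitrogen. Because that earlier swap gave a 1.4-fold lower number from compound 1 to compound 3 (0.13 log units; within the scatter), a step of similar size is expected here, namely a 1.3-fold lower number from compound 2 to compound 4 (0.13 log units; within the scatter). On this basis compound 4 is estimated at 1350 nM in this assay , most likely falling between 700 nM and 2700 nM.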

Compound 4, solubility: 1010 nM
Beside the measured number, compound 4's estimate is 1.3-fold (0.13 log units) above it; the range from low to high includes it.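

Carried to the second chain, 2-chloropyrimidin-4-yl in place of 4-chloropyrimidin-2-yl on an amine nitrogen gives, in this assay, a 1.8-fold lower number from compound 2 to compound 4 (0.25 log units; within the scatter), while the same change on the first chain gave a 1.4-fold lower number from compound 1 to compound 3 (0.13 log units; within the scatter). Both steps lie within the scatter, so the two attachments cannot be ranked on either core: the change can be carried from one core to the other without the number leaving the usual scatter, but this does not show that the change has a real effect on either core, or that it behaves differently on the two. Nothing measured here offers an explanation for these numbers.

Going by these compounds, it remains open whether the step would stay within the scatter with a longer chain joining the two amine nitrogens. Also open, on these data alone, is what the same change would do if an amine or a carboxylic acid stood on the pyrimidine ring in place of the chlorine.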